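Fluoro Replaces Hydrogen on the Anilino Group of Compound 3

The source may hold more compounds than are shown below. What is called first, only, known or untested is meant among the compounds shown, and "the series" means these compounds.

For the measured compounds named here, compound 3 `O=C(CCc1cccc2c1B(O)OC2)Nc1ccccc1` is the only member of this small set with a numerical result: in a functional assay on SK-OV-3 cells (Homo sapiens) for antiproliferative activity, read by MTT assay, with a stated time of 72 h (on this read-out lower numbers stand for stronger inhibition and higher numbers for weaker inhibition), compound 3 gives 200 nM. Compound 1 `O=C(O)CCc1cccc2c1B(O)OC2`, with hydroxy on the carbonyl carbon, reports only a limit, as compound 1 gives > 100000 nM. Compound 2 `O=C(CCc1cccc2c1B(O)OC2)NC1CCCCC1` also stops at a limit, since compound 2 gives > 100000 nM. The step of an at least 500-fold lower number from compound 2 to compound 3 (2.69 log units; beyond the scatter) is large, as is an at least 500-fold lower number from compound 1 to compound 3 (2.69 log units; beyond the scatter), while a step that the two limits leave unreadable from compound 1 to compound 2 cannot be read. Compound 4 `O=C(CCc1cccc2c1B(O)OC2)Nc1ccc(F)cc1` differs from compound 3 by fluoro in place of hydrogen on an aromatic carbon. Going by the values given here, no measured step touches a substituent on the anilino ring; the large steps all exchange the whole group on the carbonyl carbon. The step of no change at the digits printed from compound 3 to compound 4 (within the scatter) is therefore expected to remain within the scatter. Compound 4 is estimated at 200 nM, between 70 nM and 600 nM.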

Compound 4, half-maximal inhibitory concentration: 720 nM
The estimate for compound 4 lay 3.6-fold (0.56 log units) below the measured number; the measured number lies above the stated range.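

In this assay, for the compounds shown here, the anilino ring responded to a single substituent for the first time: fluoro, para to a large group, gave a 3.6-fold higher number from compound 3 to compound 4 (0.56 log units; beyond the scatter), a modest step but beyond the scatter. The 4-fluorophenyl group still stayed well ahead of cyclohexyl, with an at least 130-fold lower number from compound 2 to compound 4 (2.14 log units; beyond the scatter). Compound 2 stands at a limit of the assay, and this step therefore marks a bound rather than an exact size: the limit of > 100000 nM in this assay, at which 2 of the 4 values shown sit.

From the compounds shown here alone, whether this weakening is particular to fluoro remains open. Chloro, methoxy or an amine at this place could answer that, as could fluoro elsewhere on the ring.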